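Series notes: carbonyl substituent variation on the piperidine amide

The source may hold more compounds than are shown below. What is called first, only, known or untested is meant among the compounds shown, and "the series" means these compounds.

The three measured compounds share one core and differ only in the group on the carbonyl carbon of the ring nitrogen. Compound 2 `CCC1(OC(=O)N2CCC(Oc3ncnc(Oc4ccc(S(C)(=O)=O)nc4C)c3F)CC2)CC1` gives 83% in a functional assay on isolated protein for inhibition of Glucose-dependent insulinotropic receptor (Rattus norvegicus), read by HTRF and cAMP accumulation; a lower number here means a smaller maximal response, a higher number a larger maximal response. Compound 3 `Cc1nc(S(C)(=O)=O)ccc1Oc1ncnc(OC2CCN(C(=O)SC3CC3)CC2)c1F` gives 80% and compound 1 `Cc1nc(S(C)(=O)=O)ccc1Oc1ncnc(OC2CCN(C(=O)OC(C)(C)C(F)(F)F)CC2)c1F` gives 79%, so all three numbers lie within the scatter of one another and none can be set apart.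

The measured steps confirm this: a number 4 percentage points higher from compound 1 to compound 2 (within the scatter), a number 1 percentage points higher from compound 1 to compound 3 (within the scatter) and a number 3 percentage points lower from compound 2 to compound 3 (within the scatter). Exchanging an oxygen-linked group for a sulfur-linked ring, or a fluorinated chain for a cyclopropyl group, has left the maximal response flat.

Compound 4 `Cc1nc(S(C)(=O)=O)ccc1Oc1ncnc(OC2CCN(C(=O)C(F)(F)F)CC2)c1F` is unmeasured. Relative to compound 2 the change is a group of 4 heavy atoms (1 carbon, 3 fluorine; no ring) in place of a group of 6 heavy atoms (5 carbon, 1 oxygen; one three-membered non-aromatic ring of carbon only), on a carbonyl carbon. Within the data shown here, the entering trifluoromethyl group sits directly on the carbonyl carbon, which no measured compound shows; compound 1 carries fluorine only within a larger chain on an oxygen. Among the measured compounds shown here, every step so far on this carbonyl carbon has stayed within the scatter, so no step beyond the scatter is expected here either: a number 3 percentage points lower from compound 2 to compound 4 (within the scatter) is the estimated change. Compound 4 is therefore expected to give 80%, between 68% and 92%.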

Compound 4, largest response reached (reported as efficacy), in percent of the reference or control that the assay uses: 76%
Beside the measured number, compound 4's estimate is 4 percentage points above it; the measured number falls inside the stated range.
By their numbers in this assay, from the lowest: compounds 4, 1, 3 and 2 (each within the scatter of the next).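

Trifluoromethyl directly on the carbonyl carbon, with no linking oxygen or sulfur, leaves the maximal response in this assay unmoved against all three earlier groups (a number 7 percentage points lower from compound 2 to compound 4 (within the scatter); a number 4 percentage points lower from compound 3 to compound 4 (within the scatter); a number 3 percentage points lower from compound 1 to compound 4 (within the scatter)). The earlier compounds showed only oxygen-linked or sulfur-linked groups at this place, so among these four compounds neither such a link nor a ring in the entering group is needed to hold the response at this level. The data on hand offer no explanation for this flat response.

Among these compounds, still open is whether an amine, a carboxylic acid or a longer chain on this carbonyl carbon, whose other neighbour is the amide-type nitrogen in a ring, would stay within the scatter of these four compounds or would give the first step beyond it. The maximal response also does not tell how much of each compound is needed to reach it, so any differences among these groups in that respect remain unknown.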